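The source may report more compounds than this note shows. Statements on the series, on what has been measured and on what is new or still open speak of the compounds shown alone.

Measured so far:
- compound 1 `CC1=NN(C(=O)/C=C/c2ccccc2)C(c2ccccc2O)C1`: 29000 nM
- compound 2 `CC1=NN(C(=O)CCl)C(c2cc(Br)ccc2O)C1`: 16300 nM
- compound 3 `CC1=NN(C(=O)COc2ccc(Cl)cc2)C(c2cc(Br)cc(Br)c2O)C1`: "not active" (no number reported)

All three were tested in a functional assay on HepG2 cells (Homo sapiens) for cytotoxicity, read by MTT assay, with a stated time of 48 h; on this read-out lower numbers stand for stronger inhibition and higher numbers for weaker inhibition. Only compound 1 and compound 2 gave numbers, and those two numbers lie within the usual scatter of each other. Compound 2 therefore stands level with compound 1 on the data shown. Compound 3 gave no number at all, so it cannot be placed on that scale.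

The unmeasured compound 4 `C=CCN(CC=C)CC(=O)N1N=C(C)CC1c1cc(Br)ccc1O` is built from compound 2 by a single change: diallylamino in place of chloro on a saturated chain carbon bound to a carbonyl carbon. The rest of the structure stays the same.

Going by the values given here, no measured pair here differs in only one place, so the data offer no direct precedent for this change. Compound 1 at 29000 nM and compound 2 at 16300 nM do carry different groups on the carbonyl, yet their numbers remain close, and this points to a small step rather than a large one. Expected here is a 1.1-fold higher number from compound 2 to compound 4 (0.04 log units; within the scatter), with no clear direction beyond the scatter. Compound 3 is the counterexample, so a result without a number also remains possible. For compound 4 the estimated value in this assay is 18000 nM, with an expected range from 6000 nM to 50000 nM.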

Compound 4, half-maximal inhibitory concentration: 7870 nM
Compound 4: middle estimate off by 2.3-fold (0.36 log units), on the high side, and the stated range covers the measured number.
By their numbers in this assay, from the lowest: compound 4; then compounds 2 and 1 (each within the scatter of the next).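

In this assay, putting diallylamino in place of chloro on a saturated chain carbon bound to a carbonyl carbon gives a 2.1-fold lower number from compound 2 to compound 4 (0.32 log units; beyond the scatter). Going by these compounds alone, this is the first comparison in the set that changes only one place, so it gives this position a direct reading: a group of 7 heavy atoms can replace a single chlorine atom without losing a measurable effect, and the number moves in the favourable direction. The chloro group is therefore not required for compound 4 to give a number on this read-out, but nothing available explains why the number falls, so the step records a change and not its cause.

A single pair cannot show which part of diallylamino goes with the lower number: its nitrogen, its two double bonds or simply its size. Dipropylamino would keep the two three-carbon chains without the double bonds, and dimethylamino would keep the nitrogen with much shorter chains, so either would help separate these features at the same position on the core of compound 2.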